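The source may report more compounds than this note shows. Statements on the series, on what has been measured and on what is new or still open speak of the compounds shown alone.

Compound 1 `C[C@H](Oc1ccc(S(C)(=O)=O)cc1C(=O)N1Cc2ccc(C(F)(F)F)cc2C1)C(F)(F)F` and compound 2 `C[C@H](Oc1ccc(S(C)(=O)=O)cc1C(=O)N1Cc2cc(C(F)(F)F)cnc2C1)C(F)(F)F` share a core and differ in one ring of the bicyclic amine. In an assay on CHO cells for inhibition of sodium- and chloride-dependent glycine transporter 1 (Homo sapiens), read by scintillation counting (on this read-out higher numbers stand for an effect only at larger amounts of compound and lower numbers for an effect already at smaller amounts), compound 1 gives 21 nM and compound 2 gives 50 nM. Of these two numbers compound 2 holds the highest, and its gap to compound 1 lies beyond the usual scatter. Compound 3 `CC(C)Oc1ccc(S(C)(=O)=O)cc1C(=O)N1Cc2cc(C(F)(F)F)cnc2C1` keeps the core of compound 2 and differs only in isopropyl in place of 1-(trifluoromethyl)ethyl on an oxygen on an aromatic ring. Going by the values given here, no measured pair shows this change, so its size is uncertain; a step toward a higher number is expected, roughly a 2.6-fold higher number from compound 2 to compound 3 (0.41 log units; beyond the scatter). Compound 3 is therefore estimated at 130 nM, with a range from 45 nM to 400 nM.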

Compound 3, half-maximal effective concentration: 70 nM
Estimate against measurement, compound 3: 1.9-fold (0.27 log units) above; low and high end bracket the measured number.
By their numbers in this assay, from the lowest: compound 1; then compounds 2 and 3 (each within the scatter of the next).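

In this assay, isopropyl in place of 1-(trifluoromethyl)ethyl on an oxygen on an aromatic ring gives a 1.4-fold higher number from compound 2 to compound 3 (0.15 log units; within the scatter), a step within the scatter. At this position, then, the fluorine atoms and the defined stereocentre can leave without a change that this read-out can separate from noise. Nothing measured here accounts for this result.

Still open, on these data alone, is how a cyclopropyl group, a longer chain or an amine on this oxygen would read. Equally open, as far as these compounds go, is whether the same change on the core of compound 1 would also stay within the scatter.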